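This account rests on a few compounds, and the source may have more. Where it says the series, first, only, none or still open, it means among the compounds named here.

In a functional assay on HT-29 cells (Homo sapiens) for inhibition, read by CCK-8 assay, with a stated time of 24 h (on this read-out lower numbers stand for stronger inhibition and higher numbers for weaker inhibition), the measured compounds are:

Compound 1 `O=C1Nc2ccccc2/C1=C/c1ccc(-c2cn(-c3cccc(F)c3)nn2)cc1`: > 20000 nM, a limit of the assay
Compound 2 `Cc1cccc(-n2cc(-c3ccc(/C=C4\C(=O)Nc5ccc(F)cc54)cc3)nn2)c1`: 7320 nM
Compound 3 `O=C1Nc2ccc(F)cc2/C1=C/c1ccc(-c2cn(-c3ccccc3F)nn2)cc1`: 8980 nM

Among the measured compounds shown here, compound 3, at 8980 nM, has only one numerical neighbour, and that neighbour lies within the scatter of it: compound 2 at 7320 nM. The next compound, compound 4 `O=C1Nc2ccc(F)cc2/C1=C/c1ccc(-c2cn(-c3cccc(F)c3)nn2)cc1`, has not yet been measured. It carries 3-fluorophenyl in place of 2-fluorophenyl on an aromatic nitrogen.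

For the measured compounds named here, one measured step bears on this change, and it also concerns the group on that nitrogen: a 1.2-fold higher number from compound 2 to compound 3 (0.09 log units; within the scatter). There, 2-fluorophenyl replaced 3-methylphenyl with no effect beyond the scatter. Compound 1 also carries 3-fluorophenyl, but the core of compound 1 differs and its value is only a limit. No shift beyond the scatter is therefore expected, and the estimated step is a 1.0-fold higher number from compound 3 to compound 4 (0.00 log units; within the scatter). The estimate for compound 4 is 9000 nM, with an expected range from 4500 nM to 20000 nM.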

Compound 4, half-maximal inhibitory concentration: > 12900 nM
Compound 4 gave a limit, no number; the forecaster's own chance of this, stated with the estimate: 15%; middle value at least 1.4-fold (0.15 log units) away from the limit.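

Compound 4 gives a limit rather than a number in this assay: the limit of > 12900 nM in this assay, at which 1 of the 4 values shown sits. Among the compounds shown here, this is the first readout at this position with the shared core that does not resolve to a number: the change from 2-fluorophenyl to 3-fluorophenyl is an at least 1.4-fold higher number from compound 3 to compound 4 (0.15 log units; that floor lies within the scatter), and fluoro in place of methyl on the aromatic carbon of that group is an at least 1.7-fold higher number from compound 2 to compound 4 (0.24 log units; that floor lies within the scatter). Neither change brought a number lower than those of compound 2 and compound 3, though neither floor shows a shift beyond the scatter, and the step that joins compound 1 to compound 4 cannot be read.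

Going by these compounds, whether 3-fluorophenyl truly differs from 2-fluorophenyl or 3-methylphenyl therefore stays open. So does what an amine or a carboxylic acid on this phenyl ring would do to the number.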